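Compound 1 to compound 4: methoxy in place of hydrogen

The compounds below may be only part of what the source reports. "The series", "measured", "known", "first", "only" and "open" are said of these compounds alone.

In an ADME assay on Vero cells (Chlorocebus sabaeus) for cytotoxicity, read by neutral red uptake, with a stated time of 72 h (on this read-out lower numbers stand for stronger inhibition and higher numbers for weaker inhibition), compound 1 `Clc1ccc2c(NCCNc3nccc(Nc4ccccc4)n3)ccnc2c1` gives "not active" (no number reported), so it has no single number to anchor the comparison. Compound 3 `Clc1ccc2c(NCCNc3nccc(Nc4ccc(Br)cc4)n3)ccnc2c1` likewise gives "not active" (no number reported). Within the data shown here, compound 2 `Clc1ccc(Nc2ccnc(NCCNc3ccnc4cc(Cl)ccc34)n2)cc1` gives 15800 nM, the only numerical reading. Compound 4 `COc1ccc(Nc2ccnc(NCCNc3ccnc4cc(Cl)ccc34)n2)cc1` is still unmeasured. Its structural change is methoxy in place of hydrogen on an aromatic carbon: phenyl to 4-methoxyphenyl, para to a large group. Among the measured compounds shown here, no step between measured compounds is available, so the size of the change cannot be anchored, and no clear direction is expected in this assay. Weak inhibition is expected, and a report without a number remains plausible. For compound 4 the estimated value is 20000 nM, with an expected range of 7000 nM to 60000 nM.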

Compound 4, half-maximal inhibitory concentration: "not active" (no number reported)
No number was reported for compound 4, so the estimate cannot be set against anything.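

Compound 1 and compound 4 both lack a number, so no step can be read between them. The compounds shown leave open whether methoxy in place of hydrogen shifts the read-out at all. No evidence bears on this result.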